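Free Hydroxy Versus Benzyl Ether in a Growth Assay

This account rests on a few compounds, and the source may have more. Where it says the series, first, only, none or still open, it means among the compounds named here.

Of the compounds shown here, two have been measured in a functional assay on MCF7 cells (Homo sapiens) for inhibition, read by trypan blue exclusion, with a stated time of 72 h; on this read-out lower numbers stand for stronger inhibition of growth and higher numbers for weaker inhibition of growth. Compound 1 `CC/C(=C(/c1ccc(NC(=O)C(C)C)cc1)c1ccc(OC)cc1)c1ccc(O)cc1` carries a free hydroxy on one of its aromatic rings, and in this assay compound 1 gives 13600 nM. Compound 2 `CC/C(=C(\c1ccc(NC(=O)C(C)C)cc1)c1ccc(OC)cc1)c1ccc(OCc2ccccc2)cc1` differs from compound 1 in the geometry of its double bond and carries a benzyl ether in place of the free hydroxy. In this assay compound 2 gives > 30000 nM, which is a limit rather than a number, so compound 2 stands at the limit of > 30000 nM in this assay, at which 1 of the 2 values shown sits. Compound 3 `CC/C(=C(\c1ccc(NC(=O)C(C)C)cc1)c1ccc(OC)cc1)c1ccc(O)cc1` is compound 2 with hydrogen in place of benzyl on an oxygen on an aromatic ring, that is, benzyloxy to hydroxy. Compound 2 sits at a limit, so no measured size exists for the step to compound 3. Compound 1 shows with its free hydroxy a measurable 13600 nM, so compound 3 is expected to gain potency by an at least 3.7-fold lower number from compound 2 to compound 3 (0.57 log units; beyond the scatter). Compound 3 is estimated at 8000 nM, within 2000 nM to 30000 nM.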

Compound 3, concentration for 50% growth inhibition: 9000 nM
Compound 3: the middle estimate sits 1.1-fold (0.05 log units) below what was measured; measured number inside the range.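

Compound 3 keeps the double-bond geometry of compound 2, so in this assay the change of benzyl to hydrogen on the oxygen can be read alone, and it gives an at least 3.3-fold lower number from compound 2 to compound 3 (0.52 log units; beyond the scatter). The value of compound 2 is a limit, so this step has a smallest size but no full size: the limit of > 30000 nM in this assay, at which 1 of the 3 values shown sits. With the free hydroxy in place on both compounds, the two drawn forms of the double bond give a 1.5-fold lower number from compound 1 to compound 3 (0.18 log units; within the scatter), so the two cannot be told apart here: the fact that compounds 1 and 3 differ only in the configuration as drawn.

The compounds shown leave open how the read-out would respond to an acetyl group or a propyl chain on this oxygen. They also leave open how large the full step from benzyl to hydrogen is.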